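The source may report more compounds than this note shows. Statements on the series, on what has been measured and on what is new or still open speak of the compounds shown alone.

Measured in a functional assay on SK-BR-3 cells (Homo sapiens) for antiproliferative activity; on this read-out lower numbers stand for stronger inhibition and higher numbers for weaker inhibition:
- compound 1 `CC(C)=CCc1cc(C(=O)Nc2cc3ccc(OCC4CCCN(C)C4)c(C)c3oc2=O)ccc1O`: 1300 nM
- compound 2 `CCCNCCCOc1ccc2cc(NC(=O)c3ccc(O)c(CC=C(C)C)c3)c(=O)oc2c1C`: 990 nM
- compound 3 `CC(C)=CCc1cc(C(=O)Nc2cc3ccc(OCCCNCC(C)C)c(C)c3oc2=O)ccc1O`: 1030 nM

In this assay, compound 3 gives 1030 nM, within the scatter of both other compounds. Compound 4 `CC(C)=CCc1cc(C(=O)Nc2cc3ccc(OCCCN(C)C(C)C)c(C)c3oc2=O)ccc1O` differs from it as follows: isopropyl(methyl)amino in place of isobutylamino on a saturated chain carbon, three bonds along the chain from an oxygen on an aromatic ring. Within the data shown here, no measured step tests this exact exchange. The closest evidence comes from the three steps that alter the amine portion: a 1.3-fold lower number from compound 1 to compound 2 (0.12 log units; within the scatter), a 1.3-fold lower number from compound 1 to compound 3 (0.10 log units; within the scatter) and a 1.0-fold higher number from compound 2 to compound 3 (0.02 log units; within the scatter). All three lie within the scatter, so no change beyond the scatter is expected in this assay, and no direction is favoured. The expected outcome is a 1.0-fold higher number from compound 3 to compound 4 (0.01 log units; within the scatter). For compound 4 the estimated value is 1050 nM, with an expected range of 520 nM to 2100 nM.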

Compound 4, half-maximal inhibitory concentration: 570 nM
The estimate for compound 4 lay 1.8-fold (0.27 log units) above the measured number; measured number inside the range.
By their numbers in this assay, from the lowest: compounds 4, 2, 3 and 1 (each within the scatter of the next, the first and the last beyond it).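

In this assay, isopropyl(methyl)amino, with no hydrogen-bond donor, stays within the scatter of the amines carrying one: a 1.8-fold lower number from compound 3 to compound 4 (0.26 log units; within the scatter), and a 1.7-fold lower number from compound 2 to compound 4 (0.24 log units; within the scatter). Only the exchange of the 1-methylpiperidin-3-yl group gives a step beyond the scatter among these compounds, though a modest one: a 2.3-fold lower number from compound 1 to compound 4 (0.36 log units; beyond the scatter). Nothing available accounts for that step. Left open is how a morpholine or a dimethylamino group would read at this place, and whether a longer chain carrying isopropyl(methyl)amino would move the number beyond the scatter of compound 4.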